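A few compounds are considered here, and "the series" means these few. Any claim that something is new, unique, unknown or untested is made for them only; others in the source may bear on it.

Measured in an ADME assay on J774 cells (Mus musculus) for cytotoxicity; a lower number here means that less compound is needed, a higher number that more compound is needed for the effect:
- compound 1 `CCCCc1ccc2[nH]cc(C(=O)OC)c(=O)c2c1`: > 20000 nM (a limit)
- compound 2 `COC(=O)c1c[nH]c2ccc(OC)cc2c1=O`: 6180 nM
- compound 3 `CCOc1ccc2[nH]cc(C(=O)OC)c(=O)c2c1`: > 20000 nM (a limit)

Compound 3 gives > 20000 nM in this assay, which is a limit and not a number. It therefore sits at the limit of > 20000 nM in this assay, at which 2 of the 3 values shown sit, together with compound 1.

Compound 4 `COC(=O)c1c[nH]c2ccc(Oc3ccccc3)cc2c1=O` follows from compound 3 by phenyl in place of ethyl on an oxygen on an aromatic ring.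

The nearest measured change lies on the same oxygen: an at least 3.2-fold higher number from compound 2 to compound 3 (0.51 log units; beyond the scatter). Two further steps offer less. One is an at least 3.2-fold lower number from compound 1 to compound 2 (0.51 log units; beyond the scatter), and the other is a step that the two limits leave unreadable from compound 1 to compound 3. Among the measured compounds shown here, no measured step brings an aromatic ring onto that oxygen, so these steps carry over only loosely. A readable step to a higher number is not possible from a limit. A modest step to a lower number is expected at most, and compound 4 may well stay at the limit.

The expected outcome is an at least 1.2-fold lower number from compound 3 to compound 4 (0.09 log units; that floor lies within the scatter). For compound 4 the estimate is 16000 nM, with an expected range of 6000 nM to 20000 nM.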

Compound 4, half-maximal effective concentration: > 20000 nM
Compound 4 ended at the assay's limit; the forecaster's own chance of this, stated with the estimate: 55%; middle value at least 1.2-fold (0.09 log units) from the limit.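

Among the compounds shown here, on the oxygen on an aromatic ring, methyl remains the only group with a readable value in this assay. Phenyl in place of methyl gives an at least 3.2-fold higher number from compound 2 to compound 4 (0.51 log units; beyond the scatter), in the same direction as ethyl with an at least 3.2-fold higher number from compound 2 to compound 3 (0.51 log units; beyond the scatter), so an aromatic ring on this oxygen and a longer chain there both part from methyl in the same way. The steps among compound 1, compound 3 and compound 4 cannot be read because all three stand at the same limit: the limit of > 20000 nM in this assay, at which 3 of the 4 values shown sit.

As far as these compounds go, how far past that limit compound 3 and compound 4 lie stays open, so ethyl and phenyl cannot be ordered on this oxygen. Also open, from the compounds shown here alone, is whether an amine or a carboxylic acid on the phenyl ring would bring the number back within the readable range.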